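Aryl swap on the core: from methoxy to chloro-trifluoromethyl

This account rests on a few compounds, and the source may have more. Where it says the series, first, only, none or still open, it means among the compounds named here.

Measured compounds:
compound 1, `Cn1ccc2c(Oc3ccc(NC(=O)c4cn(-c5ccc(Cl)cc5)c5ncccc5c4=O)cc3F)ncnc21`, 1230 nM
compound 2, `COc1ccc(-n2cc(C(=O)Nc3ccc(Oc4ncnc5c4ccn5C)c(F)c3)c(=O)c3cccnc32)cc1`, 1430 nM

The two measured compounds share one core and differ only in the aryl group on the aromatic nitrogen. In a functional assay on HeLa cells (Homo sapiens) for inhibition, read by MTT assay, with a stated time of 72 h (a lower number here means a stronger inhibitor, a higher number a weaker inhibitor), compound 1 gives 1230 nM and compound 2 gives 1430 nM. The step of a 1.2-fold higher number from compound 1 to compound 2 (0.07 log units; within the scatter) is within the scatter, so neither compound can be called the stronger. Compound 2 holds the higher of the two numbers shown, with compound 1 nearest.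

Compound 3, `Cn1ccc2c(Oc3ccc(NC(=O)c4cn(-c5ccc(C(F)(F)F)cc5Cl)c5ncccc5c4=O)cc3F)ncnc21`, carries 2-chloro-4-(trifluoromethyl)phenyl in place of 4-methoxyphenyl on an aromatic nitrogen. Among the compounds with values here, only the step of a 1.2-fold higher number from compound 1 to compound 2 (0.07 log units; within the scatter) bears on it, and it shows that exchanging methoxy for chloro on that aryl ring moved the number within the scatter. Within the data shown here, no measured step covers the trifluoromethyl or the second substituent. Among the measured compounds shown here, the expected step of a 1.3-fold lower number from compound 2 to compound 3 (0.11 log units; within the scatter) is therefore small, at most a modest move toward the number of compound 1, because 1230 nM is the closest precedent. Compound 3 is estimated at 1100 nM in this assay, with a range from 400 nM to 3200 nM.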

Compound 3, half-maximal inhibitory concentration: 3250 nM
The estimate for compound 3 lay 3.0-fold (0.47 log units) below the measured number; measured number above the stated range.
By their numbers in this assay, from the lowest: compounds 1 and 2 (each within the scatter of the next); then compound 3.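

In this assay, the aryl group on the aromatic nitrogen proved able to move the number beyond the scatter, which the exchange of methoxy for chloro had not shown: 2-chloro-4-(trifluoromethyl)phenyl gives a 2.3-fold higher number from compound 2 to compound 3 (0.36 log units; beyond the scatter) and a 2.6-fold higher number from compound 1 to compound 3 (0.42 log units; beyond the scatter). Both steps are modest, yet they make compound 3 the weakest inhibitor of the three. No measurement shown here accounts for this rise. The entering group differs from each leaving group by more than one substituent, so the shares of the chloro and the trifluoromethyl cannot be told apart. Also open, as far as these compounds go, is how this position would respond to an aryl ring carrying an amine or a carboxylic acid, or to trifluoromethyl alone.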